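The compounds below may be only part of what the source reports. "The series", "measured", "known", "first", "only" and "open" are said of these compounds alone.

Measured in a functional assay on BT-549 cells (Homo sapiens) for cytotoxicity, read by fluorescence and resazurin assay, with a stated time of 72 h; on this read-out higher numbers stand for weaker inhibition and lower numbers for stronger inhibition:

Compound 1 `Nc1nc(Nc2ccc(S(N)(=O)=O)cc2)sc1C(=O)c1ccccc1[N+](=O)[O-]`: > 10000 nM, a limit.
Compound 2 `Nc1nc(Nc2ccc(S(N)(=O)=O)cc2)sc1C(=O)c1cccc(F)c1`: > 10000 nM, a limit.

Compound 2 thus stands at a limit of the assay, with no number to start from. Compound 3 `Nc1cccc(C(=O)c2sc(Nc3ccc(S(N)(=O)=O)cc3)nc2N)c1` differs from compound 2 by one change: amino in place of fluoro on an aromatic carbon. In words, amino in place of fluoro on an aromatic carbon, meta to a large group.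

Among the measured compounds shown here, only one measured step bears on this, a step that the two limits leave unreadable from compound 1 to compound 2, and it has no readable size. The wider evidence is the limit of > 10000 nM in this assay, at which 2 of the 2 values shown sit. For the measured compounds named here, no measured step therefore supports a shift in either direction, so no change beyond the scatter is expected in this assay. The expected step is a step that the limit leaves unreadable from compound 2 to compound 3.

For compound 3 the estimate is 15000 nM, with an expected range of 6000 nM to 40000 nM.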

Compound 3, half-maximal inhibitory concentration: > 10000 nM
Compound 3 was reported as a limit; the forecaster's own chance of this, stated with the estimate: 85%; the middle value is on the limit's open side.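

Among the compounds shown here, compound 3 joins compound 1 and compound 2 at a limit, so no step among the three can be read: the limit of > 10000 nM in this assay, at which 3 of the 3 values shown sit. The compounds shown leave open whether any group on the carbonyl carbon gives a readable value on the shared core.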